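This account rests on a few compounds, and the source may have more. Where it says the series, first, only, none or still open, it means among the compounds named here.

Series notes, cytotoxicity on HepG2 cells.

Compound 1 `COc1cc(/C=C2\CN(C)C/C(=C\c3ccc(Cl)cc3)C2=O)cc(OC)c1` and compound 2 `COc1cc(/C=C2\CN(C)C/C(=C\c3ccc(Br)cc3)C2=O)cc(OC)c1` share one core and differ in one place; compound 3 `CN1C/C(=C\c2ccc(Cl)cc2)C(=O)/C(=C/c2cccc([N+](=O)[O-])c2)C1` and compound 4 `CN1C/C(=C\c2ccc(Br)cc2)C(=O)/C(=C/c2cccc([N+](=O)[O-])c2)C1` share a second core and differ in the same place. In a functional assay on HepG2 cells (Homo sapiens) for cytotoxicity, read by MTT assay, with a stated time of 24 h (a lower number here means a stronger inhibitor, a higher number a weaker inhibitor), compound 1 gives 5950 nM. In this assay compound 2 gives 4840 nM. In this assay compound 3 gives 8210 nM. The difference between the two cores is not broken down here.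

The change from compound 1 to compound 2 is bromo in place of chloro on an aromatic carbon. Its size in this assay is a 1.2-fold lower number from compound 1 to compound 2 (0.09 log units; within the scatter). The change from compound 3 to compound 4 is bromo in place of chloro on an aromatic carbon. The two place descriptions agree word for word, so this is the same change made on a second core. Compound 4 has not yet been measured.

The expectation for compound 4 rests on the step from compound 1 to compound 2 in this assay, a 1.2-fold lower number from compound 1 to compound 2 (0.09 log units; within the scatter), which stayed within the scatter, and on the value of compound 3 in this assay, 8210 nM. The step from compound 3 to compound 4 in this assay is therefore expected to be a 1.2-fold lower number from compound 3 to compound 4 (0.07 log units; within the scatter). For compound 4 in this assay a value of 7000 nM is estimated, with a range from 3500 nM to 14000 nM. That this rests on a single earlier instance of the change, on a different core, is noted.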

Compound 4, half-maximal inhibitory concentration: 8800 nM
Compound 4: the middle estimate sits 1.3-fold (0.10 log units) below what was measured, and the stated range covers the measured number.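

In this assay, exchanging 4-chlorophenyl for 4-bromophenyl on the second core gives a 1.1-fold higher number from compound 3 to compound 4 (0.03 log units; within the scatter). Set beside the earlier instance of the same change on the first core, the two steps do not differ: the same change on two cores in this assay, a 1.2-fold lower number (0.09 log units; within the scatter) from compound 1 to compound 2 and a 1.1-fold higher number (0.03 log units; within the scatter) from compound 3 to compound 4, 1.3-fold (0.12 log units) apart, within the scatter of two such steps

So on these two cores the exchange of chloro for bromo leaves the number within the scatter each time, and nothing here points to the outcome depending on the core; this does not show that the same would hold on a further core, since only two pairs are available, and with both steps within the scatter no direction can be assigned to the change.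

The compounds shown carry only chloro and bromo at this place on the aromatic ring, so it remains open whether a fluoro, a methoxy, a nitrile or an amine there would give a step of similar size on both cores. Also open, as far as these compounds go, is whether the agreement between cores would survive with a longer chain in place of the methyl on the ring nitrogen, or on cell lines other than HepG2.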